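This account rests on a few compounds, and the source may have more. Where it says the series, first, only, none or still open, it means among the compounds named here.

Measured in a physicochemical assay for lipophilicity, measured as octanol-water partition; on this read-out higher numbers stand for higher lipophilicity and lower numbers for lower lipophilicity:
compound 1 `O=C(COc1cccc2ccccc12)N/N=C/c1ccccc1Br` gives 4.81
compound 2 `O=C(COc1cccc2ccccc12)N/N=C/c1ccc([N+](=O)[O-])cc1` gives 3.97
compound 3 `O=C(COc1cccc2ccccc12)N/N=C/c1ccc(F)cc1` gives 4.16

Compound 3 stands second highest of the three in this assay; its nearest neighbour is compound 2, a gap within the scatter, and compound 1 is furthest, with a number 0.65 log units lower from compound 1 to compound 3 (beyond the scatter).

The next compound is compound 4 `COc1ccc(/C=N/NC(=O)COc2cccc3ccccc23)cc1`, which differs from compound 3 by methoxy in place of fluoro on an aromatic carbon.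

Among the measured compounds shown here, no measured step puts methoxy in or takes it out, so only the size of the earlier substituent exchanges on this ring serves as a guide: a number 0.19 log units higher from compound 2 to compound 3 (within the scatter), whereas a number 0.65 log units lower from compound 1 to compound 3 (beyond the scatter). The step from compound 3 to compound 4 is expected to be small, a number 0.11 log units lower from compound 3 to compound 4 (within the scatter), at most at the edge of the scatter and downward if anything. Compound 4 is estimated at 4.05 in this assay, with a range from 3.75 to 4.35.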

Compound 4, partition coefficient: 3.77
Beside the measured number, compound 4's estimate is 0.28 log units above it, within the range that was stated.
By their numbers in this assay, from the lowest: compounds 4, 2 and 3 (each within the scatter of the next, the first and the last beyond it); then compound 1.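

With methoxy in place of fluoro on this aromatic carbon, this assay gives a number 0.39 log units lower from compound 3 to compound 4 (beyond the scatter), so a single exchange at this place now clears the scatter, unlike the earlier exchange of nitro for fluoro. Methoxy and nitro stay unresolved, with a number 0.20 log units lower from compound 2 to compound 4 (within the scatter), while the widest gap in the series is a number 1.04 log units lower from compound 1 to compound 4 (beyond the scatter). Nothing available explains these steps.

On these data alone, whether an amine or a carboxylic acid at this place would stay within the same span remains open. The high number of compound 1 also leaves bromo and its ring position unseparated.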